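A few compounds are considered here, and "the series" means these few. Any claim that something is new, unique, unknown or untested is made for them only; others in the source may bear on it.

Measured compounds:

Compound 1, `Cc1cc(C(=O)NC(C)C)nn1Cc1cc(Cl)cc2cc(-c3ccccc3)oc12`: 10 nM in an assay on CHO-K1 cells for displacement of a labelled ligand from prostaglandin E2 receptor EP1 subtype (Homo sapiens), read by scintillation counting, with a stated time of 45 min; a lower number here means a stronger inhibitor, a higher number a weaker inhibitor
Compound 2, `Cc1cc(C(N)=O)nn1Cc1cc(Cl)cc2cc(-c3ccccc3)oc12`: 5.01 nM in this assay
Compound 3, `Cc1cc(C(=O)N[C@H]2CC[C@H](O)CC2)nn1Cc1cc(Cl)cc2cc(-c3ccccc3)oc12`: 7.94 nM in this assay

All three share one core and differ only in the group carried on the amide-type nitrogen. Compound 3 sits between the other two on these numbers, but every gap is small: a 1.3-fold lower number from compound 1 to compound 3 (0.10 log units; within the scatter) and a 1.6-fold higher number from compound 2 to compound 3 (0.20 log units; within the scatter) both lie within the scatter, as does a 2.0-fold lower number from compound 1 to compound 2 (0.30 log units; within the scatter). So whether that nitrogen bears hydrogen, isopropyl or 4-hydroxycyclohexyl, this assay returns much the same result.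

Compound 4, `Cc1cc(C(=O)NC[C@H]2CCCO2)nn1Cc1cc(Cl)cc2cc(-c3ccccc3)oc12`, continues this series with another change at the same place: (oxolan-2-yl)methyl in place of 4-hydroxycyclohexyl on an amide-type nitrogen. The three measured steps are the ones that bear on it, and none of them moved the number beyond the scatter. By that record the step from compound 3 to compound 4 is expected to be a 1.0-fold higher number from compound 3 to compound 4 (0.00 log units; within the scatter), a change of no real size in either direction. Compound 4 is therefore estimated at 8 nM in this assay, with a range from 3 nM to 25 nM.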

Compound 4, half-maximal inhibitory concentration: 6.31 nM
Compound 4: middle estimate off by 1.3-fold (0.10 log units), on the high side, within the range that was stated.
By their numbers in this assay, from the lowest: compounds 2, 4, 3 and 1 (each within the scatter of the next).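

In this assay the new group brings a 1.3-fold lower number from compound 3 to compound 4 (0.10 log units; within the scatter), even though 4-hydroxycyclohexyl counts 1 hydrogen-bond donor and (oxolan-2-yl)methyl counts 0, and a ring of carbon only gives way to a five-membered ring with 1 hetero atom. The comparisons with the other two amides, a 1.3-fold higher number from compound 2 to compound 4 (0.10 log units; within the scatter) and a 1.6-fold lower number from compound 1 to compound 4 (0.20 log units; within the scatter), also stay within the scatter, so all four groups on this amide-type nitrogen now read alike, including one with no hydrogen-bond donor in the group. No measurement shown here explains this insensitivity.

On these data alone, it remains open whether a carboxylic acid, an amine or a longer alkyl chain on this nitrogen would move the number beyond the scatter. These compounds also say nothing about changes elsewhere on the shared core.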